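This account rests on a few compounds, and the source may have more. Where it says the series, first, only, none or still open, it means among the compounds named here.

Compound 1 `COc1cc(/C=C/C(=O)C2=C(/C=C/c3ccc(O)c(OC)c3)NC(=O)NC2c2ccccc2)ccc1O`: 100000 nM
Compound 2 `COc1cc(/C=C/C(=O)C2=C(/C=C/c3ccc(O)c(OC)c3)NC(=O)NC2c2ccccc2O)ccc1O`: 50000 nM
Compound 3 `COc1cc(/C=C/C(=O)C2=C(/C=C/c3ccc(O)c(OC)c3)NC(=O)NC2c2ccc(N(C)C)cc2)ccc1O`: 25000 nM

In a functional assay on HeLa cells (Homo sapiens) for cytotoxicity, read by MTT assay, with a stated time of 48 h (on this read-out lower numbers stand for stronger inhibition and higher numbers for weaker inhibition), compound 3 gives 25000 nM. Of the three numbers, it stands clearly apart from only one: the data show a 4.0-fold lower number from compound 1 to compound 3 (0.60 log units; beyond the scatter), whereas they show a 2.0-fold lower number from compound 2 to compound 3 (0.30 log units; within the scatter). The remaining measured step is a 2.0-fold lower number from compound 1 to compound 2 (0.30 log units; within the scatter). Compound 4 `COc1cc(/C=C/C(=O)C2=C(/C=C/c3ccc(O)c(OC)c3)NC(=O)NC2c2c(Cl)cccc2Cl)ccc1O` carries 2,6-dichlorophenyl in place of 4-(dimethylamino)phenyl on a saturated ring carbon. Going by the values given here, no measured compound contains chlorine, so these steps offer only a loose guide. The dimethylamino step is lost in this change, so a small move back towards higher numbers in this assay is expected, not exceeding the scatter: a 1.6-fold higher number from compound 3 to compound 4 (0.20 log units; within the scatter). For compound 4 the estimated value is 40000 nM, with an expected range of 15000 nM to 100000 nM.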

Compound 4, half-maximal inhibitory concentration: 25000 nM
Estimate against measurement, compound 4: 1.6-fold (0.20 log units) above, within the range that was stated.
By their numbers in this assay, from the lowest: compounds 3, 4, 2 and 1 (each within the scatter of the next, the first and the last beyond it).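

In this assay, compound 4 shows that a substituted aryl group without the dimethylamino group can sit on this saturated ring carbon with no loss against compound 3 (no change at the digits printed from compound 3 to compound 4 (within the scatter)). The 2,6-dichlorophenyl group is thus a second replacement for phenyl that passes the scatter (a 4.0-fold lower number from compound 1 to compound 4 (0.60 log units; beyond the scatter)), while its step from the 2-hydroxyphenyl compound stays within it (a 2.0-fold lower number from compound 2 to compound 4 (0.30 log units; within the scatter)). No available evidence accounts for these steps. The compounds shown leave open whether a single chlorine, a carboxylic acid or a morpholine on this phenyl ring would give a lower number.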